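The compounds below may be only part of what the source reports. "The series", "measured", "known", "first", "only" and "open" are said of these compounds alone.

Compound 1 `CCCNS(=O)(=O)c1ccc(Nc2ncc3c(n2)N(C2CCCC2)[C@H](CC)C(=O)N3C)cc1` gives 548 nM in a functional assay on K562 cells (Homo sapiens) for antiproliferative activity, read by CCK-8 assay, with a stated time of 72 h; a lower number here means a stronger inhibitor of growth, a higher number a weaker inhibitor of growth. Among the compounds with values here, compound 2 `CCC1C(=O)N(C)c2cnc(-n3ccc4cc(C(=O)NCC(C)C)ccc43)nc2N1c1ccn(C)n1` gives 5600 nM in this assay, the higher of the two numbers so far; its gap to compound 1 is beyond the scatter. Compound 3 `CCNC(=O)c1ccc2c(ccn2-c2ncc3c(n2)N(c2ccn(C)n2)C(CC)C(=O)N3C)c1` has not been measured; it differs from compound 2 by methyl in place of isopropyl on a saturated chain carbon bound to an amide-type nitrogen. Within the data shown here, no measured pair shows a step of this kind, so the change is expected to leave the number within the scatter, with no clear direction. For compound 3 the estimate in this assay is 5000 nM, within 2000 nM to 14000 nM, and this is expected to mean a 1.1-fold lower number from compound 2 to compound 3 (0.05 log units; within the scatter).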

Compound 3, concentration for 50% growth inhibition: 12800 nM
Beside the measured number, compound 3's estimate is 2.6-fold (0.41 log units) below it; the measured number falls inside the stated range.
By their numbers in this assay, from the lowest: compound 1; then compound 2; then compound 3.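

Replacing isobutylcarbamoyl with ethylcarbamoyl gives a 2.3-fold higher number from compound 2 to compound 3 (0.36 log units; beyond the scatter) as the first step read at this place, on a saturated chain carbon bound to an amide-type nitrogen. The position is therefore not silent: in this single pair, methyl in place of isopropyl goes with the weaker inhibitor of growth. No available data bear on the reason for this step.

As far as these compounds go, whether a longer chain would give a lower number remains open. So does the effect of an amine or a carboxylic acid at the end of the chain.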